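A Second Fluorine on the Pendant Phenyl Ring

This account rests on a few compounds, and the source may have more. Where it says the series, first, only, none or still open, it means among the compounds named here.

Compound 1 `COc1cc2c(Oc3ccc(NC(=O)c4nccc(-c5ccccc5)n4)cc3F)ccnc2cc1OCCCN1CCCCC1` gives "not determined" (no result reported) in a functional assay on A549 cells (Homo sapiens) for cytotoxicity, read by MTT assay, with a stated time of 72 h; a higher number here means a weaker inhibitor, a lower number a stronger inhibitor.
Compound 2 `COc1cc2c(Oc3ccc(NC(=O)c4nccc(-c5ccc(C)cc5)n4)cc3F)ccnc2cc1OCCCN1CCCCC1` gives 900 nM in this assay.
Compound 3 `COc1cc2c(Oc3ccc(NC(=O)c4nccc(-c5ccc(F)cc5)n4)cc3F)ccnc2cc1OCCCN1CCCCC1` gives "not determined" (no result reported) in this assay.
Compound 4 `COc1cc2c(Oc3ccc(NC(=O)c4nccc(-c5ccc(F)cc5F)n4)cc3F)ccnc2cc1OCCCN1CCCCC1` has not yet been measured in this assay.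

Compound 3 therefore stands without a number in this assay, and compound 1 is in the same position; the only number among these three is that of compound 2, which carries a methyl on the pendant phenyl ring rather than a fluoro. For the measured compounds named here, no pair of measured compounds differs in a single place, so no measured step gives a scale for what one substituent change on that ring does here.

Compound 4 differs from compound 3 by fluoro in place of hydrogen on an aromatic carbon. Going by the values given here, with no measured step to lean on, the expectation is a step of no more than the usual scatter in this assay, in no particular direction. Compound 4 is estimated at 1000 nM in this assay, with a range from 250 nM to 4000 nM.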

Compound 4, half-maximal inhibitory concentration: 470 nM
The estimate for compound 4 lay 2.1-fold (0.33 log units) above the measured number; measured number inside the range.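

In this assay, for the compounds shown here, compound 4 gives the first number for a pendant ring that carries fluoro, and that number cannot be told apart from the one for the 4-methylphenyl ring: replacing 4-methylphenyl with 2,4-difluorophenyl gives a 1.9-fold lower number from compound 2 to compound 4 (0.28 log units; within the scatter). Steps involving compound 1 or compound 3 cannot be read, so the added fluoro, ortho to a large group, has no measured effect of its own here. No measurement available for these compounds bears on this result.

As far as these compounds go, it remains open what the fluoro alone contributes at this place on the ring. From the compounds shown here alone, it is also open whether a different group there, such as an amine or a carboxylic acid, would move the number beyond the scatter.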